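This account rests on a few compounds, and the source may have more. Where it says the series, first, only, none or still open, it means among the compounds named here.

For the measured compounds named here, in a physicochemical assay for solubility, read by HPLC (on this read-out lower numbers stand for lower solubility and higher numbers for higher solubility), compound 2 (`CC(=O)N1CCN(c2nc(=O)c3cc(C(F)(F)F)cc([N+](=O)[O-])c3s2)CC1`) gives 83.9 ug/mL and stands highest of the two measured numbers, with compound 1 (`O=C(c1ccc(Cl)cc1)N1CCN(c2nc(=O)c3cc(C(F)(F)F)cc([N+](=O)[O-])c3s2)CC1`) at 5.19 ug/mL as its only neighbour. Compound 3 (`Cc1ccc(C(=O)N2CCN(c3nc(=O)c4cc(C(F)(F)F)cc([N+](=O)[O-])c4s3)CC2)cc1`) is not yet measured and carries 4-methylphenyl in place of methyl on a carbonyl carbon relative to compound 2. Going by the values given here, the one measured step that bears on this is a 16-fold higher number from compound 1 to compound 2 (1.21 log units; beyond the scatter) with methyl in place of 4-chlorophenyl on a carbonyl carbon. That step is large and the change at hand runs the other way. Among the compounds with values here, compound 3 carries 4-methylphenyl where compound 1 carries 4-chlorophenyl, and no measured step separates those two groups. A large step toward lower numbers is therefore expected in this assay and the estimated move is a 12-fold lower number from compound 2 to compound 3 (1.08 log units; beyond the scatter) for this change. The expected value for compound 3 is 7 ug/mL with an estimated range from 2.5 ug/mL to 20 ug/mL in this read-out.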

Compound 3, solubility: 6.7 ug/mL
Compound 3: the middle estimate sits 1.0-fold (0.02 log units) above what was measured; measured number inside the range.
By their numbers in this assay, from the lowest: compounds 1 and 3 (each within the scatter of the next); then compound 2.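

Working notes on the series: in this assay, the change on the carbonyl carbon gives a 13-fold lower number from compound 2 to compound 3 (1.10 log units; beyond the scatter), so a large step at this position now appears with 4-methylphenyl as well as with 4-chlorophenyl. Methyl in place of chloro on an aromatic carbon gives a 1.3-fold higher number from compound 1 to compound 3 (0.11 log units; within the scatter) and leaves compound 1 and compound 3 undistinguished on this read-out. Nothing shown here gives a measured reason for either step.

The compounds shown leave open whether the large step tracks the aromatic ring itself or simply a larger group, and a cyclohexyl group or a longer chain such as hexyl on the carbonyl carbon would separate the two. Also open, on these data alone, is how an aryl group carrying an amine or a carboxylic acid would read in this assay on this carbonyl carbon.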